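The source may hold more compounds than are shown below. What is called first, only, known or untested is meant among the compounds shown, and "the series" means these compounds.

Compound 1 `O=S(=O)(/C=C/c1ccc(O)c(O)c1)CC1CCCCC1` in a functional assay, read by fluorescence and spectrophotometry, with a stated time of 1 h (a lower number here means that less compound is needed, a higher number that more compound is needed for the effect), gives 7500 nM
Compound 2 `CCCCCCS(=O)(=O)/C=C/c1ccc(O)c(O)c1` in this assay gives 7300 nM

Compound 2 stands level with compound 1 on these numbers, and the two cannot be separated within the scatter. Compound 3 `O=S(=O)(/C=C/c1ccc(O)c(O)c1)CC1CCCN1` carries pyrrolidin-2-yl in place of pentyl on a saturated chain carbon bound to a sulfonyl sulfur, counted in full as pyrrolidin-2-yl in place of pentyl on a saturated chain carbon bound to a sulfonyl sulfur and not yet measured.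

For the measured compounds named here, only one measured step bears on this change, and only in part. It is a 1.0-fold lower number from compound 1 to compound 2 (0.01 log units; within the scatter) and it exchanges cyclohexyl for pentyl, both made of carbon alone. Going by the values given here, no measured compound has a nitrogen in this group, so the data hold no direct precedent for the change. The flat step from cyclohexyl to pentyl therefore sets no firm size, and a wide range is warranted. A modest move toward a higher number is expected, though no change beyond the scatter remains possible.

The estimated step is a 1.6-fold higher number from compound 2 to compound 3 (0.22 log units; within the scatter) in this assay and remains an expectation only. For compound 3 the expected value is 12000 nM (estimated range 4000 nM to 40000 nM).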

Compound 3, half-maximal effective concentration: 13800 nM
Compound 3: the middle estimate sits 1.2-fold (0.06 log units) below what was measured, and the stated range covers the measured number.
By their numbers in this assay, from the lowest: compounds 2, 1 and 3 (each within the scatter of the next).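

With pyrrolidin-2-yl on a saturated chain carbon bound to a sulfonyl sulfur, the series now holds a group at this place that carries a nitrogen, a hydrogen-bond donor and a hydrogen-bond acceptor, and this assay reads a 1.9-fold higher number from compound 2 to compound 3 (0.28 log units; within the scatter) and a 1.8-fold higher number from compound 1 to compound 3 (0.26 log units; within the scatter) as the two steps to it, both within the scatter. The earlier pair compared only all-carbon groups, whereas these steps show that pentyl, cyclohexyl and pyrrolidin-2-yl cannot be separated at this place, so the nitrogen-bearing ring gives no number distinct from either all-carbon group. Nothing independent of these numbers bears on the result, and no reason for it can be given.

Still open, going by these compounds, is whether any group at this place moves the number beyond the scatter, for example an open-chain primary amine, a carboxylic acid, a piperidin-2-yl ring or a longer chain such as octyl. The three compounds also share the same core, so they say nothing about how this place behaves with that core altered.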